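The source may report more compounds than this note shows. Statements on the series, on what has been measured and on what is new or still open speak of the compounds shown alone.

In an assay on Sf21 cells for inhibition of MAP kinase-interacting serine/threonine-protein kinase 1 (Homo sapiens), read by luminescence and ADP-Glo, with stated times of 10 min and 40 min, tested at 500 nM (a lower number here means less inhibition, a higher number more inhibition at the concentration tested (going by the name of the read-out)), the measured compounds are:
Compound 1 `O=C(c1ccc(-c2ccc3ncc(-c4ccc5cnccc5c4)n3c2)cc1)N1CCC(N2CCCCC2)CC1` gives 92.9%.
Compound 2 `O=C(c1ccc(-c2ccc3ncc(-c4ccc5ncccc5c4)n3c2)cc1)N1CCC(N2CCCCC2)CC1` gives 62.8%.
Compound 3 `O=C(c1ccc(-c2ccc3ncc(-c4cnc5ccccc5c4)n3c2)cc1)N1CCOCC1` gives 71%.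

Compound 3 thus stands within the usual scatter of compound 2 and clearly below compound 1 in this assay. Compound 4 `O=C(c1ccc(-c2ccc3ncc(-c4cnc5ccccc5c4)n3c2)cc1)N1CCC(N2CCCCC2)CC1` differs from compound 3 by 4-(piperidin-1-yl)piperidin-1-yl in place of morpholin-4-yl on a carbonyl carbon. Among the compounds with values here, the only measured step, a number 30.1 percentage points lower from compound 1 to compound 2 (beyond the scatter), concerns a different part of the molecule and does not bear on this amide change. Compounds 1 and 2 both carry the 4-(piperidin-1-yl)piperidin-1-yl amide and span a wide band around the value of compound 3, so no change beyond the scatter is expected from a number 7 percentage points higher from compound 3 to compound 4 (within the scatter). Compound 4 is therefore estimated at 78%, within 55% to 95%.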

Compound 4, a percentage reported as inhibition, at one concentration (the size of the read-out at that concentration, not a potency): 71%
The estimate for compound 4 lay 7 percentage points above the measured number; the range from low to high includes it.
By their numbers in this assay, from the lowest: compounds 2, 3 and 4 (each within the scatter of the next); then compound 1.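

The amide position on the carbonyl carbon accepted the larger group in this assay, with no change at the digits printed from compound 3 to compound 4 (within the scatter) for 4-(piperidin-1-yl)piperidin-1-yl in place of morpholin-4-yl. With that amide held fixed, quinolin-3-yl gave a number 8.2 percentage points higher from compound 2 to compound 4 (within the scatter) against quinolin-6-yl and a number 21.9 percentage points lower from compound 1 to compound 4 (beyond the scatter) against isoquinolin-6-yl, so only isoquinolin-6-yl stands apart among these three aromatic groups. No evidence is available to explain these results. From the compounds shown here alone, whether isoquinolin-6-yl keeps that standing with the morpholin-4-yl amide remains open. So does how an open-chain dimethylamino group on the carbonyl carbon would compare.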